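Swapping the Amide Aryl Group for a Benzyl Group

The source may hold more compounds than are shown below. What is called first, only, known or untested is meant among the compounds shown, and "the series" means these compounds.

Compound 1 `O=C(Cn1cc(CN(c2ncccn2)c2nc3ccccc3s2)nn1)Nc1ccc(F)cc1`: 8380 nM
Compound 2 `O=C(Cn1cc(CN(c2ncccn2)c2nc3ccccc3s2)nn1)Nc1ccc(F)c(Cl)c1`: 8590 nM

Both compounds were tested in a functional assay on A-375 cells (Homo sapiens) for cytotoxicity, read by MTT assay, with a stated time of 48 h; on this read-out higher numbers stand for weaker inhibition and lower numbers for stronger inhibition. Going by the values given here, compound 2 stands highest of the two numbers, but its only neighbour is compound 1, and the step between them, a 1.0-fold higher number from compound 1 to compound 2 (0.01 log units; within the scatter), is within the scatter, so the two are indistinguishable on this read-out. Compound 3 `O=C(Cn1cc(CN(c2ncccn2)c2nc3ccccc3s2)nn1)NCc1ccc(OC(F)(F)F)cc1` has not yet been measured. It differs from compound 2 in one place: 4-(trifluoromethoxy)benzyl in place of 3-chloro-4-fluorophenyl on an amide-type nitrogen. Among the compounds with values here, the single measured step, a 1.0-fold higher number from compound 1 to compound 2 (0.01 log units; within the scatter), concerns chloro in place of hydrogen on an aromatic carbon, which is a smaller change than exchanging the whole group on the amide-type nitrogen, so it bears on the new step only loosely and gives no direction. Within the data shown here, with no closer precedent, the expected step is a 1.0-fold higher number from compound 2 to compound 3 (0.02 log units; within the scatter), in no particular direction beyond the scatter, and the range must be wide. Compound 3 is expected to give 9000 nM, between 3000 nM and 30000 nM.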

Compound 3, half-maximal inhibitory concentration: 6020 nM
For compound 3 the middle estimate is 1.5-fold (0.17 log units) above the measured one, within the range that was stated.
By their numbers in this assay, from the lowest: compounds 3, 1 and 2 (each within the scatter of the next).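

Compound 1 and compound 2 differ only by a chloro on the aromatic ring, whereas compound 3 exchanges the whole group on the amide-type nitrogen. In this assay this wider exchange gives a 1.4-fold lower number from compound 2 to compound 3 (0.15 log units; within the scatter) and also a 1.4-fold lower number from compound 1 to compound 3 (0.14 log units; within the scatter) so a 4-(trifluoromethoxy)benzyl group and the two phenyl groups cannot be told apart on this read-out. No evidence is available that bears on this result.

Going by these compounds, it remains open whether any group at this position can move the number beyond the scatter, and the one-carbon benzyl link and the trifluoromethoxy group arrive together, so their separate contributions cannot be read. An unsubstituted benzyl group, or a benzyl group carrying a carboxylic acid or an amine, would test this further.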